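Swapping trifluoromethyl for methyl on a benzimidazole-piperazine amide

The source may report more compounds than this note shows. Statements on the series, on what has been measured and on what is new or still open speak of the compounds shown alone.

Measured so far:
- compound 1, `Cc1cccc(Cn2c(CN3CCN(C(=O)c4ccc(C(F)(F)F)cc4)CC3)nc3ccccc32)c1`: 22.9%
- compound 2, `CC(C)CCn1c(CN2CCN(C(=O)c3ccco3)CC2)nc2ccccc21`: 42.1%

In an assay on isolated protein for inhibition of aldehyde dehydrogenase 1A1 (Homo sapiens), read by spectrophotometry, tested at 10 uM (on this read-out lower numbers stand for less inhibition and higher numbers for more inhibition at the one concentration tested (going by the name of the read-out)), compound 1 stands lowest of the two numbers; the nearest is compound 2, whose value lies higher by a gap beyond the usual scatter. Compound 3, `Cc1ccc(C(=O)N2CCN(Cc3nc4ccccc4n3Cc3cccc(C)c3)CC2)cc1`, has not yet been measured. It differs from compound 1 in one place: methyl in place of trifluoromethyl on an aromatic carbon. Among the compounds with values here, no measured pair here shows this change, so nothing directly tells how large a step to expect. The step from compound 1 to compound 3 is expected to be small, likely within the scatter, as a number 3.1 percentage points higher from compound 1 to compound 3 (within the scatter). For compound 3 the estimated value is 26%, in the range 8% to 46%.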

Compound 3, a percentage reported as inhibition, at one concentration (the size of the read-out at that concentration, not a potency): 64.9%
Compound 3: middle estimate off by 38.9 percentage points, on the low side; measured number outside the range, above it.
By their numbers in this assay, from the lowest: compound 1; then compound 2; then compound 3.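

Within this assay, the change from 4-(trifluoromethyl)phenyl to 4-methylphenyl gives a number 42 percentage points higher from compound 1 to compound 3 (beyond the scatter) even though the rest of the molecule stays the same. This shows that the read-out is sensitive to the group on this aromatic carbon, para to a large group, something the comparison of compound 1 with compound 2 could not show, as they differ in more than one place. No measurement here offers a reason for the size of this step. From the compounds shown here alone, whether a nitrile, a methoxy group or a plain hydrogen on this carbon would read closer to compound 1 or compound 3 remains open. So does whether this swap would have a similar effect on a different core.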